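The source may report more compounds than this note shows. Statements on the series, on what has been measured and on what is new or still open speak of the compounds shown alone.

Compounds measured so far: compound 1 `CC(C(=O)NCc1ccc(C(F)(F)F)cc1N1CCC(C(F)(F)F)CC1)c1ccc(NS(C)(=O)=O)c(F)c1` gives 0.4 nM; compound 2 `CC(C(=O)NCc1ccc(C(F)(F)F)cc1N1CCC(Cc2ccccc2)CC1)c1ccc(NS(C)(=O)=O)c(F)c1` gives 1.4 nM; compound 3 `CCCCCCOc1cc(C(C)(F)F)ccc1CNC(=O)C(C)c1ccc(NS(C)(=O)=O)c(F)c1` gives 0.8 nM, all in an assay on CHO cells for antagonist activity at transient receptor potential cation channel subfamily V member 1 (Homo sapiens), read by FLIPR; on this read-out higher numbers stand for weaker inhibition and lower numbers for stronger inhibition.

Among these three, compound 1 has the lowest number in this assay. Compound 3 comes nearest, a gap that stays within the scatter, so the two cannot be told apart; compound 2 is furthest, with a 3.5-fold higher number from compound 1 to compound 2 (0.54 log units; beyond the scatter).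

Compound 4 `CC(C(=O)NCc1ccc(C(F)(F)F)cc1Cl)c1ccc(NS(C)(=O)=O)c(F)c1` has not yet been measured. It differs from compound 1 in one place: chloro in place of 4-(trifluoromethyl)piperidin-1-yl on an aromatic carbon. Within the data shown here, no measured step covers this change. Among the measured compounds shown here, the only step recorded, from compound 1 to compound 2, alters the group on the saturated ring and is modest, while compound 3 shows that a quite different substituent at this part of the core can still sit within the scatter of compound 1. Neither speaks directly to stripping the whole ring down to a single chlorine. Removing that much of the molecule is expected to weaken inhibition somewhat more than either comparison, so for compound 4 a step of a 25-fold higher number from compound 1 to compound 4 (1.40 log units; beyond the scatter) is estimated. Compound 4 is therefore expected to give about 10 nM, within a range from 2 nM to 60 nM.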

Compound 4, inhibition constant: 4 nM
Estimate against measurement, compound 4: 2.5-fold (0.40 log units) above; the measured number falls inside the stated range.
By their numbers in this assay, from the lowest: compounds 1, 3 and 2 (each within the scatter of the next, the first and the last beyond it); then compound 4.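

In this assay, replacing the whole 4-(trifluoromethyl)piperidin-1-yl group with chloro costs a real but bounded amount, a 10-fold higher number from compound 1 to compound 4 (1.00 log units; beyond the scatter), and compound 4 still gives 4 nM with a single chlorine at this aromatic carbon. Among these compounds, the only earlier step, a 3.5-fold higher number from compound 1 to compound 2 (0.54 log units; beyond the scatter), changed a group on the saturated ring while keeping the ring in place, whereas this result shows that inhibition does not depend on having that ring at this position at all. No supporting data are available to explain the size of this step.

The compounds shown do not separate the contribution of the ring from that of its trifluoromethyl group, a question that an unsubstituted piperidin-1-yl group at this carbon would address. They also leave open how a morpholine or pyrrolidine ring, or a small group such as fluoro, methyl or methoxy, would compare with chloro and with the 4-(trifluoromethyl)piperidin-1-yl group at this position.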